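Ethoxy to methoxy on the aryl ether of compound 1

The compounds below may be only part of what the source reports. "The series", "measured", "known", "first", "only" and "open" are said of these compounds alone.

Measured in a physicochemical assay for lipophilicity, read by HPLC, at pH 7.5; a lower number here means a more polar compound, a higher number a more lipophilic compound:
Compound 1, `CCOc1ccccc1-c1ccc(-c2nc3cnccc3c(N[C@H](CC)C(N)=O)c2C#N)cc1`, gives 3.
Compound 2, `CCOc1ccccc1-c1ccc(-c2nc3cnccc3c(NC(C(N)=O)C3CC3)c2C#N)cc1`, gives 3.
Compound 3, `CCOc1ccccc1-c1ccc(-c2nc3cnccc3c(N[C@@H]3CCOC3=O)c2C#N)cc1`, gives 2.7.

Compound 1 stands level with compound 2 at the digits printed, the two together the highest of the three numbers in this assay; compound 3 is the furthest from it, a number 0.30 log units lower from compound 1 to compound 3 (within the scatter). The step of no change at the digits printed from compound 1 to compound 2 (within the scatter) and the step of a number 0.30 log units lower from compound 2 to compound 3 (within the scatter) both lie within the scatter, so the three measured compounds, which differ only in the group on the nitrogen on the aromatic ring, are in practice indistinguishable in this assay.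

Compound 4, `CC[C@@H](Nc1c(C#N)c(-c2ccc(-c3ccccc3OC)cc2)nc2cnccc12)C(N)=O`, differs from compound 1 elsewhere: hydrogen in place of methyl on a saturated chain carbon bound to an oxygen on an aromatic ring. Among the compounds with values here, none of the measured steps touches the ethoxy group; each exchanges the substituent on the amine nitrogen, and each stays within the scatter. Within the data shown here, there is therefore no measured step that bears directly on this change, and the expectation rests on the change itself as counted. A loss of one carbon from an ethoxy to a methoxy is expected to move compound 4 by a number 0.40 log units lower from compound 1 to compound 4 (beyond the scatter) in this assay, a small step at or near the edge of the scatter, in the downward direction. Compound 4 is accordingly expected to give 2.6 in this assay, with a range from 2.2 to 3.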

Compound 4, distribution coefficient: 2.7
Compound 4: middle estimate off by 0.10 log units, on the low side; measured number inside the range.
By their numbers in this assay, from the lowest: compounds 3, 4, 1 and 2 (each within the scatter of the next).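

Within the data shown here, the change from ethoxy to methoxy is the first step in this set made away from the group on the nitrogen on the aromatic ring, and in this assay it reads a number 0.30 log units lower from compound 1 to compound 4 (within the scatter) for hydrogen in place of methyl on a saturated chain carbon bound to an oxygen on an aromatic ring. This step therefore does not separate the two compounds in this assay, so a single change at the 2-ethoxyphenyl group joins the changes on the nitrogen in staying within the scatter. No measured evidence is available to account for the size of this step.

The compounds shown leave open whether a longer chain such as propoxy, or a group carrying an amine or a carboxylic acid, in place of the ethoxy would move the number in this assay beyond the scatter. Also open, going by these compounds, is how methoxy reads when paired with the 2-oxooxolan-3-yl group of compound 3, a pairing that would show whether the changes at the two places add up.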